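The source may hold more compounds than are shown below. What is called first, only, known or untested is meant among the compounds shown, and "the series" means these compounds.

Measured in a functional assay on HepG2 cells (Homo sapiens) for cytotoxicity, with a stated time of 72 h; a higher number here means that more compound is needed for the effect, a lower number that less compound is needed:

- Compound 1 `C=C[C@@](C)(/C=C/c1ccc(O)cc1)CCCO` gives > 52000 nM
- Compound 2 `C=C[C@@](C)(/C=C/c1ccc(O)cc1)CC/C=C/C(=O)OCC` gives > 52000 nM
- Compound 3 `C=C[C@@](C)(/C=C/c1ccc(O)cc1)CC/C=C/C(=O)c1ccccc1` gives > 52000 nM

Each of these entries is a limit of the assay, not a number. Compound 3 therefore stands only at a limit, > 52000 nM. It shares that place with the whole set, as the record shows: the limit of > 52000 nM in this assay, at which 3 of the 3 values shown sit.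

Compound 4 `C=C[C@@](C)(/C=C/c1ccc(O)cc1)CC/C=C/C#N` has not yet been measured. It differs from compound 3 by one change: cyano in place of benzoyl on a double-bonded chain carbon bound to a double-bonded chain carbon. In short, cyano takes the place of benzoyl on a double-bonded chain carbon bound to a double-bonded chain carbon.

Among the measured compounds shown here, two measured steps bear on this change: a step that the two limits leave unreadable from compound 1 to compound 2 and a step that the two limits leave unreadable from compound 2 to compound 3. Neither has a readable size, and neither produced a number. Compound 3 is the closest guide, since its step that the two limits leave unreadable from compound 2 to compound 3 also altered the group at this end and the reading stayed at the limit. No step beyond the scatter is therefore expected in this assay, and the estimated step is a step that the limit leaves unreadable from compound 3 to compound 4. For compound 4 the estimated value is 60000 nM, with an expected range of 35000 nM to 100000 nM.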

Compound 4, half-maximal effective concentration: > 52000 nM
Compound 4: only a limit was reported; the forecaster's own chance of this, stated with the estimate: 85%; the middle value lies beyond the limit too.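

Among the compounds shown here, compound 1, compound 2, compound 3 and compound 4 all sit at the same limit, not at a number, so no step to compound 4 can be read: the limit of > 52000 nM in this assay, at which 4 of the 4 values shown sit. What stays open is how far each compound lies beyond that limit in this assay, and whether swapping the end group changes the reading at all.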